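Shortening the acid chain on the ring nitrogen

The source may report more compounds than this note shows. Statements on the series, on what has been measured and on what is new or still open speak of the compounds shown alone.

Compounds measured so far:
compound 1, `CC(CC(=O)O)N1Cc2ccc(NC(=O)CCCC3CCNCC3)cc2C1=O`: 5400 nM
compound 2, `O=C(O)CCCN1Cc2ccc(NC(=O)CCCC3CCNCC3)cc2C1=O`: 51000 nM
compound 3, `O=C(O)CCCN1Cc2ccc(NC(=O)CC3CCNCC3)cc2C1=O`: 1800 nM

In a functional assay on a cell-free system (Platelet, plasma, Homo sapiens) for inhibition (a lower number here means a stronger inhibitor, a higher number a weaker inhibitor), compound 3 gives 1800 nM, the lowest of the three numbers; compound 1 sits nearest, and compound 2 is furthest away, with the steps to both beyond the scatter. Compound 4, `O=C(O)CCN1Cc2ccc(NC(=O)CC3CCNCC3)cc2C1=O`, differs from compound 3 by carboxy in place of carboxymethyl on a saturated chain carbon, two bonds along the chain from an amide-type nitrogen in a ring. Among the measured compounds shown here, no measured pair shows exactly this shortening. The step that comes closest is a 9.4-fold higher number from compound 1 to compound 2 (0.98 log units; beyond the scatter), a change of the same chain on the same nitrogen, while a 28-fold lower number from compound 2 to compound 3 (1.45 log units; beyond the scatter) alters the other side of the core and does not speak to it. For the measured compounds named here, the single relevant step is modest and points to the chain on the ring nitrogen mattering, with compound 1 carrying an acid spaced like that of compound 4 and standing better than compound 2. Going by the values given here, a modest lowering of the number is therefore expected for compound 4, a 2.3-fold lower number from compound 3 to compound 4 (0.35 log units; beyond the scatter), with a wide margin since no direct precedent exists. Compound 4 is estimated at 800 nM, within 200 nM to 3500 nM.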

Compound 4, half-maximal inhibitory concentration: 7400 nM
Estimate against measurement, compound 4: 9.3-fold (0.97 log units) below, and the stated range ends below it.
By their numbers in this assay, from the lowest: compound 3; then compounds 1 and 4 (each within the scatter of the next); then compound 2.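

In this assay, shortening 3-carboxypropyl to 2-carboxyethyl on the amide-type nitrogen in a ring gives a 4.1-fold higher number from compound 3 to compound 4 (0.61 log units; beyond the scatter), so with this amide side chain the longer of the two acid chains has the lower number. Among the compounds shown here, this is the first reading of chain length alone at this position: the earlier step on the same nitrogen, a 9.4-fold higher number from compound 1 to compound 2 (0.98 log units; beyond the scatter), replaced a branched 1-(carboxymethyl)ethyl group with a straight chain and so changed length and branching together. Nothing available accounts for the change.

The compounds shown leave open whether a 4-carboxybutyl chain on this nitrogen would lower the number further or raise it again. They also leave open how the 1-(carboxymethyl)ethyl group would behave with the shorter amide side chain carrying piperidin-4-yl.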